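This account rests on a few compounds, and the source may have more. Where it says the series, first, only, none or still open, it means among the compounds named here.

Among the measured compounds shown here, compound 2, `COc1cc(-c2cc(/C=C/C(=O)c3ccc(N)cc3)[nH]n2)cc(OC)c1OC`, gives 4050 nM in a functional assay on DU-145 cells (Homo sapiens) for inhibition, read by sulforhodamine B assay, with a stated time of 48 h (a higher number here means a weaker inhibitor of growth, a lower number a stronger inhibitor of growth), the highest of the two values known so far. Compound 1, `COc1ccc(-c2cc(/C=C/C(=O)c3ccc(N)cc3)[nH]n2)cc1`, gives 3460 nM in this assay, and the gap between compound 1 and compound 2 lies within the scatter. Compound 3, `COc1ccc(-c2cc(/C=C/C(=O)c3ccc(N)cc3)[nH]n2)cc1OC`, differs from compound 2 by hydrogen in place of methoxy on an aromatic carbon. For the measured compounds named here, no step between measured compounds exists here, so the change is expected to bring no step beyond the scatter, giving a 1.1-fold lower number from compound 2 to compound 3 (0.04 log units; within the scatter). For compound 3 the estimate in this assay is 3700 nM, with a range from 1800 nM to 7500 nM.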

Compound 3, concentration for total growth inhibition: 13500 nM
Compound 3: the middle estimate sits 3.6-fold (0.56 log units) below what was measured, and the stated range ends below it.
By their numbers in this assay, from the lowest: compounds 1 and 2 (each within the scatter of the next); then compound 3.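

Taking a methoxy off compound 2 does not leave this assay unchanged: it gives a 3.3-fold higher number from compound 2 to compound 3 (0.52 log units; beyond the scatter) and so a weaker inhibitor of growth. Adding a methoxy to compound 1 also weakens inhibition, giving a 3.9-fold higher number from compound 1 to compound 3 (0.59 log units; beyond the scatter) in the same assay. The effect of a methoxy on this ring therefore has no single direction, since both removing and adding one raise the number, and compound 3 is weaker than both neighbours.

As far as these compounds go, whether a hydroxyl or a fluorine on this aromatic carbon would act like hydrogen or like methoxy remains open. Nothing available explains why compound 3 stands apart.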